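Replacing a Carbamoylphenyl Ether with a 3,5-Difluorophenyl Ether

A few compounds are considered here, and "the series" means these few. Any claim that something is new, unique, unknown or untested is made for them only; others in the source may bear on it.

Measured compounds:
- compound 1, `CC(C)[C@H](NC(=O)COc1cccc2ccccc12)C(=O)N[C@@H](CC(=O)O)C(=O)COc1ccc(C(N)=O)cc1`, gives > 100000 nM
- compound 2, `CC(C)[C@H](NC(=O)COc1cccc2ccccc12)C(=O)N[C@@H](CC(=O)O)C(=O)COc1ccc(OC(F)(F)F)cc1`, gives 29100 nM
- compound 3, `CC(C)[C@H](NC(=O)COc1cccc2ccccc12)C(=O)N[C@@H](CC(=O)O)C(=O)COc1c(F)cccc1F`, gives 2040 nM

All three share one core and differ only in the aryl group on the ether oxygen. In a functional assay on Jurkat cells (Homo sapiens) (a higher number here means a weaker inhibitor, a lower number a stronger inhibitor), compound 1 gives > 100000 nM, which is a limit of the assay rather than a number (the limit of > 100000 nM in this assay, at which 1 of the 3 values shown sits). Compound 1 thus stands at the weak end of the set with no exact value. Compound 2 is stronger, an at least 3.4-fold lower number from compound 1 to compound 2 (0.53 log units; beyond the scatter). Compound 3 is stronger still: an at least 49-fold lower number from compound 1 to compound 3 (1.69 log units; beyond the scatter) and a 14-fold lower number from compound 2 to compound 3 (1.15 log units; beyond the scatter).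

Compound 4, `CC(C)[C@H](NC(=O)COc1cccc2ccccc12)C(=O)N[C@@H](CC(=O)O)C(=O)COc1cc(F)cc(F)c1`, has not been measured in this assay. It differs from compound 1 as follows: 3,5-difluorophenyl in place of 4-carbamoylphenyl on an oxygen on a saturated carbon. The step from compound 1 to compound 3 bears most directly on it, since both exchanges remove the 4-carbamoylphenyl for a difluorophenyl; the step from compound 1 to compound 2 shows that even a smaller change lowers the number. A large lowering is therefore expected, an at least 12-fold lower number from compound 1 to compound 4 (1.09 log units; beyond the scatter), though whether a 3,5-difluorophenyl reaches the level of the 2,6-difluorophenyl in compound 3 cannot be read from these compounds. Compound 4 is estimated at 8000 nM, within a range from 2000 nM to 40000 nM.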

Compound 4, half-maximal inhibitory concentration: > 100000 nM
Compound 4: a limit, no number; the forecaster's own chance of this, stated with the estimate: 10%; middle value at least 12-fold (1.09 log units) from the limit.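

The reading for compound 4 is a limit of the assay and not a number, and compound 1 sits at the same limit, so the step between these two compounds cannot be read: the limit of > 100000 nM in this assay, at which 2 of the 4 values shown sit.

The informative comparison is with compound 3, which carries the same two fluorines on the aryl ring. Moving from 2,6-difluorophenyl to 3,5-difluorophenyl gives an at least 49-fold higher number from compound 3 to compound 4 (1.69 log units; beyond the scatter), so at this position in this assay, where the fluorines stand on the ring matters, and having two of them on the ring is not enough. The 3,5-difluorophenyl also falls behind the 4-(trifluoromethoxy)phenyl, with an at least 3.4-fold higher number from compound 2 to compound 4 (0.53 log units; beyond the scatter), which shows that losing the 4-carbamoylphenyl does not by itself secure a lower number.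

Going by these compounds, how far compound 4 lies beyond its limit remains unknown, and so does whether the gain in compound 3 depends on fluorine at all. A plain phenyl, or chlorine atoms or methyl groups in place of the two fluorines of compound 3, would be needed to settle that, and these compounds say nothing about them.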